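Pyridin-3-yl for pyridin-4-yl: solubility notes

This account rests on a few compounds, and the source may have more. Where it says the series, first, only, none or still open, it means among the compounds named here.

Measured compounds:
compound 1, `CCOC(=O)c1ccc(Nc2ccnc(-c3ccncc3)n2)cc1`, in a physicochemical assay for solubility, in phosphate buffer (on this read-out lower numbers stand for lower solubility and higher numbers for higher solubility), gives 52000 nM
compound 2, `CCOC(=O)c1cccc(Nc2ccnc(-c3ccncc3)n2)c1`, in this assay gives 46000 nM
compound 3, `CCOC(=O)c1ccc(Nc2ccnc(-c3cccnc3)n2)cc1`, in this assay gives 61000 nM

Compound 4, `CCOC(=O)c1cccc(Nc2ccnc(-c3cccnc3)n2)c1`, is not yet measured. Compound 1 and compound 2 are built from the same atoms joined differently; the difference between the two cores is not broken down here. Compound 3 carries the change pyridin-3-yl in place of pyridin-4-yl on an aromatic carbon relative to compound 1, and in this assay that gave a 1.2-fold higher number from compound 1 to compound 3 (0.07 log units; within the scatter). Compound 4 carries pyridin-3-yl in place of pyridin-4-yl on an aromatic carbon relative to compound 2; the place of the change is described in the same words for both pairs, so it is the same change. The three measured values all lie within the usual scatter of one another, so no order among them is read.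

The step from compound 2 to compound 4 in this assay is expected to be a 1.2-fold higher number from compound 2 to compound 4 (0.08 log units; within the scatter). Among the measured compounds shown here, this rests on the single earlier instance, compound 1 to compound 3, which gave a 1.2-fold higher number from compound 1 to compound 3 (0.07 log units; within the scatter). Compound 4 is therefore estimated at 55000 nM. Its expected range runs from 30000 nM to 100000 nM. One precedent is a thin base, and the two cores differ in more than one place, so the range is kept wide.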

Compound 4, solubility: 92000 nM
Compound 4: middle estimate off by 1.7-fold (0.22 log units), on the low side, within the range that was stated.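

Pyridin-3-yl in place of pyridin-4-yl gives a 2.0-fold higher number from compound 2 to compound 4 (0.30 log units; within the scatter) in this assay and gave a 1.2-fold higher number from compound 1 to compound 3 (0.07 log units; within the scatter) on the other core, with both steps lying within the scatter. The change can therefore be carried between these two cores without a readable shift in this read-out, but two pairs do not show that it has no effect, that its size is the same on both cores, or how it would behave on any other core. Nothing on hand bears on why the steps come out as they do.

Going by these compounds, all four compounds carry the ethyl ester, so it stays open whether the change reads the same with a carboxylic acid or an amide in its place. Also open, on these data alone, is how a pyridin-2-yl group would read on an aromatic carbon of the same six-membered aromatic ring with 2 nitrogen, on either core.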